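The source may report more compounds than this note shows. Statements on the series, on what has been measured and on what is new or still open speak of the compounds shown alone.

Measured in a functional assay on A549 cells (Homo sapiens) for cytotoxicity, read by sulforhodamine B assay; a higher number here means a weaker inhibitor of growth, a lower number a stronger inhibitor of growth
compound 1 `Cc1ccc2c(c1)CCCN2c1nc(Cl)nc2ccccc12` gives 43 nM
compound 2 `Cc1ccc2c(c1)CCCN2c1nc(C)nc2ccccc12` gives 211 nM

Compound 2 holds the higher of the two numbers, so it is the weaker inhibitor of growth of this pair. The open case is compound 3 `Cc1nc(N2CCCc3cc(Br)ccc32)c2ccccc2n1`, which differs from compound 2 by bromo in place of methyl on an aromatic carbon. Going by the values given here, the only measured step, a 4.9-fold higher number from compound 1 to compound 2 (0.69 log units; beyond the scatter), also exchanges methyl and chloro, but on a different carbon, so it offers weak guidance. A small shift to a lower number is expected in this assay, with no step beyond the scatter. The estimated step is a 1.2-fold lower number from compound 2 to compound 3 (0.09 log units; within the scatter). For compound 3 the expected value is 170 nM, with an estimated range of 60 nM to 500 nM.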

Compound 3, concentration for 50% growth inhibition: 211 nM
Compound 3: middle estimate off by 1.2-fold (0.09 log units), on the low side; measured number inside the range.
By their numbers in this assay, from the lowest: compound 1; then compounds 2 and 3 (each within the scatter of the next).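

In this assay, bromo in place of methyl on the aromatic carbon of the six-membered ring of carbon only gives no change at the digits printed from compound 2 to compound 3 (within the scatter). At this position, methyl and bromo therefore cannot be told apart, unlike the exchange of chloro and methyl on a different carbon, which gave a 4.9-fold higher number from compound 1 to compound 2 (0.69 log units; beyond the scatter). Nothing available accounts for this match between methyl and bromo.

As far as these compounds go, whether an amine or a carboxylic acid at this carbon would also leave the number unchanged remains open. Also open, from the compounds shown here alone, is whether bromo here, combined with chloro on the other carbon, would stay close to compound 1 at 43 nM.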